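The source may report more compounds than this note shows. Statements on the series, on what has been measured and on what is new or still open speak of the compounds shown alone.

Compound 1, `CN(C)CCCCCn1c2c(c3ccccc31)C(=O)c1c[n+]([O-])c3ccccc3c1C2=O`, is examined in a toxicity assay on L02 cells (Homo sapiens) for cytotoxicity, read by MTT assay, with a stated time of 72 h (on this read-out higher numbers stand for weaker inhibition and lower numbers for stronger inhibition), where compound 1 gives 240 nM. Among the three compounds measured, compound 1 holds the second highest number. Compound 3, `CC1(C)OC[C@H](Cn2cc(Cn3c4c(c5ccccc53)C(=O)c3c[n+]([O-])c5ccccc5c3C4=O)nn2)O1`, gives 470 nM, which lies within the scatter of compound 1. Among the measured compounds shown here, compound 2, `CN1CCN(CCCCn2c3c(c4ccccc42)C(=O)c2c[n+]([O-])c4ccccc4c2C3=O)CC1`, gives 80 nM, and the step of a 3.0-fold lower number from compound 1 to compound 2 (0.48 log units; beyond the scatter) is beyond the scatter, so compound 2 is the only measured compound that is separated from compound 1.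

Compound 4, `CCCN1CCN(CCCCn2c3c(c4ccccc42)C(=O)c2c[n+]([O-])c4ccccc4c2C3=O)CC1`, differs from compound 1 in one place: 4-propylpiperazin-1-yl in place of (dimethylamino)methyl on a saturated chain carbon, four bonds along the chain from an aromatic nitrogen. For the measured compounds named here, the step that bears on this is the one from compound 1 to compound 2, where 4-methylpiperazin-1-yl replaced (dimethylamino)methyl on a saturated chain carbon, four bonds along the chain from an aromatic nitrogen, and the number fell, a 3.0-fold lower number from compound 1 to compound 2 (0.48 log units; beyond the scatter). Going by the values given here, compound 4 carries the same piperazine ring at the same place, with a propyl group in place of the methyl group on its far nitrogen, and no measured pair shows what that longer group does. The modest fall seen for compound 2 is therefore taken as the guide, and a step of similar size toward a lower number is expected in this assay, a 2.4-fold lower number from compound 1 to compound 4 (0.38 log units; beyond the scatter). For compound 4 the estimated value in this assay is 100 nM, with a range from 40 nM to 250 nM.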

Compound 4, half-maximal inhibitory concentration: 6830 nM
Estimate against measurement, compound 4: 68-fold (1.83 log units) below, and the stated range ends below it.
By their numbers in this assay, from the lowest: compound 2; then compounds 1 and 3 (each within the scatter of the next); then compound 4.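

In this assay, the piperazine ring does not by itself set the direction of the change on a saturated chain carbon, four bonds along the chain from an aromatic nitrogen. With 4-methylpiperazin-1-yl in place of (dimethylamino)methyl the number fell, a 3.0-fold lower number from compound 1 to compound 2 (0.48 log units; beyond the scatter), whereas with 4-propylpiperazin-1-yl it rose, a 28-fold higher number from compound 1 to compound 4 (1.45 log units; beyond the scatter). The only difference between the two piperazines is ethyl in place of hydrogen on a saturated chain carbon bound to an amine nitrogen in a ring, and that small extension gives an 85-fold higher number from compound 2 to compound 4 (1.93 log units; beyond the scatter), so at this position the outer end of the group decides the result, and on this read-out a higher number stands for weaker inhibition.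

No measurement is at hand that explains this sharp rise. Going by these compounds, whether the number climbs gradually with the length of that outer group or jumps at one point remains open, as does what an ethyl or a butyl group in place of the propyl group would give.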